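Nitro-to-amino swap on a trimethoxyphenyl amide and ester pair

This account rests on a few compounds, and the source may have more. Where it says the series, first, only, none or still open, it means among the compounds named here.

Measured so far, in a functional assay on MDA-MB-231 cells (Homo sapiens) for antiproliferative activity, read by MTT assay, with a stated time of 72 h; on this read-out higher numbers stand for weaker inhibition and lower numbers for stronger inhibition:
compound 1 `COc1ccc(NC(=O)c2cc(OC)c(OC)c(OC)c2)cc1[N+](=O)[O-]` gives 31000 nM
compound 2 `COc1ccc(NC(=O)c2cc(OC)c(OC)c(OC)c2)cc1N` gives 18600 nM
compound 3 `COc1ccc(C(=O)Oc2cc(OC)c(OC)c(OC)c2)cc1[N+](=O)[O-]` sits at a limit of the assay, > 100000 nM

For the measured compounds named here, the only counted step, (amino in place of nitro on an aromatic carbon), gives a 1.7-fold lower number from compound 1 to compound 2 (0.22 log units; within the scatter). The difference between the core of compound 1 and the core of compound 3 is not broken down here; the two values show compound 1 with a number and compound 3 with a limit only.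

Compound 4 `COc1ccc(C(=O)Oc2cc(OC)c(OC)c(OC)c2)cc1N` carries the same change, (amino in place of nitro on an aromatic carbon), on the core of compound 3; the place is the same word for word as in the step from compound 1 to compound 2.

For compound 4 the expected step is a number no higher from compound 3 to compound 4 (the limit leaves the size open), set beside the measured 1.7-fold lower number from compound 1 to compound 2 (0.22 log units; within the scatter), and it rests on that one step only. Because compound 3 sits at the limit of > 100000 nM in this assay, at which 1 of the 3 values shown sits, a limit is again likely for compound 4 rather than a number. Compound 4 is estimated at 100000 nM, between 40000 nM and 300000 nM.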

Compound 4, half-maximal inhibitory concentration: > 100000 nM
Compound 4 was reported as a limit; the forecaster's own chance of this, stated with the estimate: 55%; the middle value sits exactly at the limit.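

In this assay, for the compounds shown here, compound 3 and compound 4 both stand at the same limit of the assay, so no step from compound 3 to compound 4 can be read: the limit of > 100000 nM in this assay, at which 2 of the 4 values shown sit.

As far as these compounds go, whether amino in place of nitro on an aromatic carbon changes the number on the core of compound 3 remains open.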